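Working notes on a three-compound set, pending one value

A few compounds are considered here, and "the series" means these few. Any claim that something is new, unique, unknown or untested is made for them only; others in the source may bear on it.

Measured so far:
- compound 1, `C=C[C@@](C)(/C=C/c1ccc(OC(=O)CCCC)cc1)CCC=C(C)C`; in a functional assay on IMR-32 cells (Homo sapiens) for inhibition, with a stated time of 48 h, tested at 50 uM (on this read-out higher numbers stand for more inhibition of growth at the one concentration tested and lower numbers for less inhibition of growth), compound 1 gives 21%
- compound 2, `COc1ccccc1/C=C/[C@@](C)(/C=C/c1ccc(O)cc1)CCC=C(C)C`; in this assay compound 2 gives 68%

Compound 2 holds the higher of the two numbers; compound 1 sits below it by a gap that lies beyond the scatter. The two measured compounds differ in more than one place, so no single-change step between measured compounds is available, and no cause for their gap can be drawn from these numbers.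

Compound 3, `CC(C)=CCC[C@@](C)(/C=C/c1ccc(N)cc1)/C=C/c1ccc(O)cc1`, is the next to be measured in this assay. Against compound 2 the change is 4-aminophenyl in place of 2-methoxyphenyl on a double-bonded chain carbon bound to a double-bonded chain carbon. Among the compounds with values here, with no measured single-change step to lean on, the step of a number 8 percentage points lower from compound 2 to compound 3 (within the scatter) is expected to be small, a change in neither direction beyond the scatter. Compound 3 is therefore estimated at 60%, within 35% to 85%.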

Compound 3, percent growth inhibition at one concentration: 28%
Compound 3: the middle estimate sits 32 percentage points above what was measured, outside the stated range (below it).
By their numbers in this assay, from the lowest: compounds 1 and 3 (each within the scatter of the next); then compound 2.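

In this assay the set now has its first single-change step, a number 40 percentage points lower from compound 2 to compound 3 (beyond the scatter), so the group on a double-bonded chain carbon bound to a double-bonded chain carbon is shown to matter for growth inhibition at the one concentration tested. The change from 2-methoxyphenyl to 4-aminophenyl replaces the ring substituent and moves its location on the ring in a single step, and the entering group also carries a hydrogen-bond donor that the leaving group lacks, so these features cannot be separated here. No available measurement accounts for the size of this step.

Still open, from the compounds shown here alone, is whether the substituent or its location on the ring matters more, which 4-methoxyphenyl and 2-aminophenyl at this place would help separate. Going by these compounds, it is also open how unsubstituted phenyl would compare with compound 2 here.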